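Expected Activity of Compound 4 in HeLa Cells

The source may hold more compounds than are shown below. What is called first, only, known or untested is meant among the compounds shown, and "the series" means these compounds.

Compound 1 `O=C(NCCNS(=O)(=O)c1cc(-c2ccccc2Oc2ccc(O)c(O)c2)cs1)Nc1cc(C(F)(F)F)cc(C(F)(F)F)c1`: > 20000 nM
Compound 2 `CC(C)c1ccc(Oc2ccc(O)c(O)c2)c(-c2ccsc2S(=O)(=O)NCCNC(=S)Nc2ccc([N+](=O)[O-])cc2)c1`: > 20000 nM
Compound 3 `O=C(NCCNS(=O)(=O)c1ccc(-c2ccccc2Oc2ccc([N+](=O)[O-])c([N+](=O)[O-])c2)s1)Nc1cc(C(F)(F)F)cc(C(F)(F)F)c1`: > 50000 nM

Of the compounds shown here, three have been measured in a functional assay on HeLa cells (Homo sapiens) for inhibition, read by CCK-8 assay, with a stated time of 48 h (on this read-out higher numbers stand for weaker inhibition and lower numbers for stronger inhibition), and none of them gave a number. Compound 1 sits at a limit of this assay, > 20000 nM. Compound 2 also sits at a limit, > 20000 nM. Compound 3 stands at a limit as well, > 50000 nM, and of the three values shown only this one reaches that far; the other two rest at the limit of > 20000 nM in this assay, at which 2 of the 3 values shown sit, while compound 3 alone rests at the limit of > 50000 nM in this assay, at which 1 of the 3 values shown sits. No step between any two of these compounds can be counted, so nothing of size or direction is known from the measured set.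

Compound 4 `O=C(NCCNS(=O)(=O)c1ccc(-c2ccccc2Oc2ccc(O)c(O)c2)s1)Nc1cc(C(F)(F)F)cc(C(F)(F)F)c1` differs from compound 3 in one place: 3,4-dihydroxyphenyl in place of 3,4-dinitrophenyl on an oxygen on an aromatic ring. Compound 1 already carries this same 3,4-dihydroxyphenyl group and stopped at > 20000 nM, which gives no reason to expect a gain. The step is therefore expected to be none beyond the scatter of this assay, with compound 4 estimated to remain at a limit, an expectation summarised as a number no higher from compound 3 to compound 4 (the limit leaves the size open). For compound 4 the estimate in this assay is 50000 nM, with a range from 15000 nM to 200000 nM.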

Compound 4, half-maximal inhibitory concentration: > 20000 nM
Compound 4: only a limit was reported; the forecaster's own chance of this, stated with the estimate: 85%; the middle value is on the limit's open side.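

In this assay compound 4 gave only a limit, > 20000 nM. Going by these compounds alone, compound 3 also gave only a limit, > 50000 nM, so no step between compound 3 and compound 4 can be read. The four compounds shown leave open whether 3,4-dihydroxyphenyl in place of 3,4-dinitrophenyl changes inhibition at all, and at what concentration any of them reaches half-maximal inhibition.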